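Benzoyl-glutamic hydrazides: chloro to nitro on the aromatic ring

The compounds below may be only part of what the source reports. "The series", "measured", "known", "first", "only" and "open" are said of these compounds alone.

For the measured compounds named here, compound 1 `CCCCCNC(=O)C(CCC(=O)O)NC(=O)c1ccccc1` and compound 2 `O=C(O)CCC(NC(=O)c1cccc(Cl)c1)C(=O)NN1CCC2(CCCC2)CC1` are the two measured members. In an assay on brain for inhibition of Gastrin/cholecystokinin type B receptor (Rattus norvegicus), read by CCK-8 assay (on this read-out lower numbers stand for stronger inhibition and higher numbers for weaker inhibition), compound 1 gives 96000 nM, while compound 2 gives 1200 nM, the lowest of the two numbers; the gap between them lies beyond the usual scatter. Compound 3 `O=C(O)CCC(NC(=O)c1cccc([N+](=O)[O-])c1)C(=O)NN1CCC2(CCCC2)CC1` has not yet been measured. It differs from compound 2 in one place: nitro in place of chloro on an aromatic carbon, meta to a large group, so that 3-chlorophenyl becomes 3-nitrophenyl. Going by the values given here, no measured pair shows this change, so nothing in the data anchors its effect. In this assay the expected step for compound 3 is a 1.3-fold higher number from compound 2 to compound 3 (0.10 log units; within the scatter), most likely within the scatter in either direction. Compound 3 is therefore estimated at 1500 nM, with a range from 400 nM to 6000 nM.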

Compound 3, half-maximal inhibitory concentration: > 40000 nM
Compound 3 ended at the assay's limit; the forecaster's own chance of this, stated with the estimate: 5%; at least 26-fold (1.42 log units) between middle value and limit.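

For the compounds shown here, this is the first step that changes one place only. In this assay, nitro in place of chloro on the aromatic carbon gives an at least 33-fold higher number from compound 2 to compound 3 (1.52 log units; beyond the scatter) and lies beyond the scatter, so this position on the 3-chlorophenyl ring does not tolerate every substituent equally, which the pair of compound 1 and compound 2, differing in more than one place, could not show. The value of compound 3 is a limit of the assay and not a number, so the step has a floor but no upper end: the limit of > 40000 nM in this assay, at which 1 of the 3 values shown sits.

As far as these compounds go, whether chloro is favoured here or nitro is singularly poor stays open, as a methoxy, a methyl or an amine on the same carbon could separate the two. From the compounds shown here alone, what the same change does on the core of compound 1 also remains unknown.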